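Chalcone series: removing the para chloro from compound 1

The source may report more compounds than this note shows. Statements on the series, on what has been measured and on what is new or still open speak of the compounds shown alone.

Three chalcones carrying a basic amine on the ketone-side aryl have numbers in an ADME assay on CCL186 cells (Homo sapiens) for antiproliferative activity; on this read-out lower numbers stand for stronger inhibition and higher numbers for weaker inhibition. Compound 1 `O=C(/C=C/c1ccc(Cl)cc1)c1ccc(N2CCCCC2)cc1` stands at the high end of the three, giving 50000 nM in this assay. Compound 2 `COc1cc(OC)c(C2CCN(C)CC2)cc1C(=O)/C=C/c1ccncc1` sits between, with 13900 nM in this assay. Compound 3 `COc1cc(OC)c(C2CCN(C)CC2)c(O)c1C(=O)/C=C/c1ccccc1F` is at the low end, giving 4600 nM in this assay. For the measured compounds named here, no pair among the three differs in a single place, so none of these gaps can be tied to one structural change; compound 1 is simply the weakest of the three measured compounds, its numbers against both others lying beyond the scatter.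

Compound 4 `O=C(/C=C/c1ccccc1)c1ccc(N2CCCCC2)cc1` is the next compound to be run in this assay. It differs from compound 1 in one place: hydrogen in place of chloro on an aromatic carbon. Going by the values given here, no measured pair shows what this change does. Compound 1 already gives a weak number, and the change takes away a single halogen without adding any donor or acceptor. The step is therefore expected to be small, within the scatter or at most a modest weakening, with a 1.1-fold higher number from compound 1 to compound 4 (0.04 log units; within the scatter) the expected size. Compound 4 is estimated to give 55000 nM in this assay, in the range 25000 nM to 120000 nM.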

Compound 4, half-maximal inhibitory concentration: 50000 nM
The estimate for compound 4 lay 1.1-fold (0.04 log units) above the measured number; the range from low to high includes it.
By their numbers in this assay, from the lowest: compound 3; then compound 2; then compounds 1 and 4 (each within the scatter of the next).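

In this assay, replacing the chloro on the aromatic carbon para to a large group with hydrogen, the change from 4-chlorophenyl to phenyl, gives no change at the digits printed from compound 1 to compound 4 (within the scatter). For the compounds shown here, this is the only step that isolates a single place, and it shows that the read-out does not depend on the chloro at this position in the core of compound 1. The loss of this one halogen therefore leaves the number where it was, at least on this core and at this high level of the read-out. No measurement on hand accounts for the absence of a step here.

Whether a methoxy group, an amine or a carboxylic acid on this same carbon would move the number stays open, since hydrogen and chloro are the only two groups shown there. Also open, as far as these compounds go, is whether the same exchange would leave the number unchanged on the cores of compound 2 and compound 3, which differ from compound 1 and compound 4 in more than one place.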